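The source may report more compounds than this note shows. Statements on the series, on what has been measured and on what is new or still open speak of the compounds shown alone.

The measured compounds:
Compound 1, `CCN(Cc1cccs1)C(=O)COc1ccc(C)cc1`, gives 8 nM
Compound 2, `Cc1ccc(OCC(=O)N(Cc2cccs2)c2ncco2)cc1`, gives 0.3 nM
Compound 3, `C=CCN(Cc1cccs1)C(=O)COc1ccc(C)cc1`, gives 20 nM

In an assay on HEK293 cells for agonist activity at transient receptor potential cation channel subfamily M member 8 (Homo sapiens), read by fluorescence and calcium flux, with a stated time of 15 min (on this read-out higher numbers stand for an effect only at larger amounts of compound and lower numbers for an effect already at smaller amounts), compound 3 stands at the highest of the three numbers. Its nearest neighbour is compound 1, and the step of a 2.5-fold higher number from compound 1 to compound 3 (0.40 log units; beyond the scatter) separates them; its furthest neighbour is compound 2, separated by the step of a 67-fold higher number from compound 2 to compound 3 (1.82 log units; beyond the scatter).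

Compound 4, `Cc1ccc(OCC(=O)N(Cc2cccs2)c2ncccn2)cc1`, has not yet been measured. It differs from compound 3 in one place: pyrimidin-2-yl in place of allyl on an amide-type nitrogen.

Two of the measured steps bear on this change. The step of a 27-fold lower number from compound 1 to compound 2 (1.43 log units; beyond the scatter) shows that an aromatic ring on the amide-type nitrogen in place of a chain went with a much lower number, and the step of a 67-fold higher number from compound 2 to compound 3 (1.82 log units; beyond the scatter) shows the reverse exchange going with a much higher number. Pyrimidin-2-yl, like 1,3-oxazol-2-yl, is an aromatic ring on that same nitrogen, so compound 4 is expected to move downward by a large step, a 20-fold lower number from compound 3 to compound 4 (1.30 log units; beyond the scatter). Whether it reaches the number of compound 2 cannot be told from these three compounds. For compound 4 the estimate in this assay is 1 nM, within a range from 0.2 nM to 6 nM.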

Compound 4, half-maximal effective concentration: 3700 nM
For compound 4 the middle estimate is 3700-fold (3.57 log units) below the measured one; measured number outside the range, above it.
By their numbers in this assay, from the lowest: compound 2; then compound 1; then compound 3; then compound 4.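

At this amide-type nitrogen, an aromatic ring as such does not set the number: in this assay, pyrimidin-2-yl brings a 190-fold higher number from compound 3 to compound 4 (2.27 log units; beyond the scatter) and a 460-fold higher number from compound 1 to compound 4 (2.67 log units; beyond the scatter), placing it above both chain-bearing compounds, whereas 1,3-oxazol-2-yl lies below them. The two aromatic rings are separated by a 12000-fold higher number from compound 2 to compound 4 (4.09 log units; beyond the scatter), the largest step among these four compounds, so at this position the identity of the ring matters more than the earlier contrast of chain and ring suggested. Nothing available here accounts for this difference in the effects of the two rings.

The compounds shown leave open whether the ring's size or its hetero atoms go with the change, and whether pyridin-2-yl, phenyl or 1,3-thiazol-2-yl on the same nitrogen would fall near compound 2, near compound 4 or somewhere in the wide range that these two compounds span. They also leave open whether the same order of groups would hold if the thiophene-bearing chain or the methyl on the aromatic ether were exchanged for another group, such as a chlorine atom.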